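The source may report more compounds than this note shows. Statements on the series, on what has been measured and on what is new or still open speak of the compounds shown alone.

Compound 3 `Cc1ccc2[nH]c(C(=O)N[C@H]3CN(S(=O)(=O)c4ccccc4)C[C@@H]3C(=O)N[C@H]3CCCN(C)C3)cc2c1` gives 99% in a functional assay on HEK293 cells for agonist activity at growth hormone secretagogue receptor type 1 (Homo sapiens), read by HTRF and inositol phosphate accumulation, with a stated time of 90 min, in the presence of a further agent that is not named here (a higher number here means a larger maximal response, a lower number a smaller maximal response), the highest number of the three measured, though its steps to the others lie within the scatter. Compound 1 `Cc1ccc2[nH]c(C(=O)N[C@H]3CN(S(=O)(=O)c4ccccc4)C[C@@H]3C(=O)NCCN(C)C)cc2c1` gives 93%, and compound 2 `Cc1ccc2[nH]c(C(=O)N[C@H]3CN(S(=O)(=O)c4ccccc4)C[C@@H]3C(=O)N[C@@H]3CCCN(C)C3)cc2c1` gives 91%; the steps of a number 2 percentage points lower from compound 1 to compound 2 (within the scatter), a number 6 percentage points higher from compound 1 to compound 3 (within the scatter) and a number 8 percentage points higher from compound 2 to compound 3 (within the scatter) are all within the scatter, compounds 2 and 3 differing only in configuration as drawn (the fact that compounds 2 and 3 differ only in the configuration as drawn). Compound 4 `Cc1ccc2[nH]c(C(=O)N[C@H]3CN(S(=O)(=O)c4ccccc4)C[C@@H]3C(=O)N[C@H]3CCCNC3)cc2c1` differs from compound 3 by hydrogen in place of methyl on an amine nitrogen in a ring. Within the data shown here, no measured step touches the amine nitrogen in the ring, and every step so far is within the scatter, so in this assay compound 4 is expected to show no step beyond the scatter, a number 4 percentage points lower from compound 3 to compound 4 (within the scatter). Compound 4 is thus estimated at 95%, within 82% to 106%.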

Compound 4, largest response reached (Emax), in percent of the reference or control that the assay uses: 98%
Estimate against measurement, compound 4: 3 percentage points below; low and high end bracket the measured number.
By their numbers in this assay, from the lowest: compounds 2, 1, 4 and 3 (each within the scatter of the next).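

Among these compounds, the first step at the amine nitrogen in the ring, hydrogen in place of methyl, gives a number 1 percentage points lower from compound 3 to compound 4 (within the scatter) in this assay, so the methyl on that nitrogen can go without a step beyond the scatter. The other two steps also stay within it: a number 5 percentage points higher from compound 1 to compound 4 (within the scatter), and a number 7 percentage points higher from compound 2 to compound 4 (within the scatter). The last of these also carries the configuration at the ring carbon: the fact that compounds 2 and 3 differ only in the configuration as drawn. On these data alone, it remains open whether an acetyl or a benzyl group on that nitrogen would leave the maximal response in the same range. The same holds for an oxygen in place of that nitrogen.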